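The compounds below may be only part of what the source reports. "The series", "measured", "known", "first", "only" and "open" are said of these compounds alone.

Measured so far:
compound 1 `CN(Cc1ccc(OCCCN)cc1)c1nc2ccc(Oc3ccccc3)cc2s1` in an assay on cells for inhibition of Voltage-dependent T-type calcium channel subunit alpha-1H (Homo sapiens), read by FLIPR and calcium flux, with stated times of 600 s and 300 s; on this read-out lower numbers stand for stronger inhibition and higher numbers for weaker inhibition: 95000 nM
compound 2 `NCCCOc1ccc(CNc2nc3ccc(Oc4cccc(C(F)(F)F)c4)cc3s2)cc1` in this assay: 171000 nM

Compound 2 carries the highest of the two numbers in this assay; compound 1 lies a short distance below it, inside the usual scatter, so no order between them is claimed. Compound 3 `NCCCOc1ccc(CNc2nc3ccc(Oc4ccccc4)cc3s2)cc1` is not yet measured. It differs from compound 2 by hydrogen in place of trifluoromethyl on an aromatic carbon. Within the data shown here, no measured pair shows this change. The expected step from compound 2 to compound 3 is a 1.4-fold lower number from compound 2 to compound 3 (0.15 log units; within the scatter), small and not clearly beyond the scatter. Compound 3 is therefore estimated at 120000 nM in this assay, within 45000 nM to 320000 nM.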

Compound 3, half-maximal inhibitory concentration: > 1000000 nM
Compound 3 was reported as a limit (the forecaster's own chance of this, stated with the estimate: 25%); middle value at least 8.3-fold (0.92 log units) away from the limit.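

In this assay compound 3 gives > 1000000 nM, a limit and not a number. Trifluoromethyl on this aromatic carbon therefore matters, since hydrogen in its place gives an at least 5.8-fold higher number from compound 2 to compound 3 (0.76 log units; beyond the scatter). Hydrogen in place of methyl on the nitrogen gives an at least 10-fold higher number from compound 1 to compound 3 (1.02 log units; beyond the scatter), so each of the two single changes leading to compound 3 moves the read-out the same way.

Going by these compounds, with compound 3 reported as a limit, the full size of both steps stays open. Also open, on these data alone, is whether a chlorine atom or a methyl group on this aromatic carbon would act as trifluoromethyl does.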